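This account rests on a few compounds, and the source may have more. Where it says the series, first, only, none or still open, it means among the compounds named here.

Measured so far in a functional assay on C6 cells (Rattus norvegicus) for cytotoxicity, read by MTT assay, with a stated time of 24 h, tested at 50 ug/mL; a lower number here means a stronger effect, a higher number a weaker effect of the compound at the concentration tested:
compound 1 `O=C(CSc1nnnn1-c1ccccc1)N/N=c1/scc(-c2ccccc2)n1-c1ccccc1` gives 36.7%
compound 2 `COc1ccc(-c2cs/c(=N/NC(=O)CSc3ncccn3)n2-c2ccccc2)cc1` gives 66.5%
compound 3 `COc1ccc(-c2cs/c(=N/NC(=O)CSc3nnc(C)s3)n2-c2ccccc2)cc1` gives 31.5%

Compound 3 stands lowest of the three numbers. Compound 1 lies within the scatter of compound 3, so no order between the two can be read; compound 2 lies well beyond it. For the measured compounds named here, the single step among the measured compounds, a number 35 percentage points lower from compound 2 to compound 3 (beyond the scatter), concerns the group on the sulfur and leaves the aromatic ring carrying the methoxy untouched. Compound 4 `Cc1ccc(-c2cs/c(=N/NC(=O)CSc3nnc(C)s3)n2-c2ccccc2)cc1` differs from compound 3 by methyl in place of methoxy on an aromatic carbon. Going by the values given here, no measured step touches this exchange, so nothing argues for a shift in either direction. The expected step of a number 1.5 percentage points higher from compound 3 to compound 4 (within the scatter) is therefore none beyond the scatter. Compound 4 is estimated at 33%, with a range from 20% to 48%.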

Compound 4, a percentage reported as activity, at one concentration (the size of the read-out at that concentration, not a potency): 40.6%
Beside the measured number, compound 4's estimate is 7.6 percentage points below it; measured number inside the range.
By their numbers in this assay, from the lowest: compounds 3, 1 and 4 (each within the scatter of the next); then compound 2.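

With 5-methyl-1,3,4-thiadiazol-2-yl held on the sulfur, methyl in place of methoxy on the aromatic carbon gives a number 9.1 percentage points higher from compound 3 to compound 4 (within the scatter) in this assay, so no difference can be read for this exchange. The oxygen of the 4-methoxyphenyl group is thus not shown to matter to this read-out, unlike the large step seen at the group on the sulfur. No measurement bears on the reason for this result. From the compounds shown here alone, whether chlorine, an amine or a carboxylic acid at this position would give a readable step remains open. Also open, going by these compounds, is whether the exchange reads the same with pyrimidin-2-yl on the sulfur.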